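Chain substituent at the ring carbon: hydroxyethyl replacement

The source may hold more compounds than are shown below. What is called first, only, known or untested is meant among the compounds shown, and "the series" means these compounds.

Measured in a functional assay on LNCaP cells (Homo sapiens) for antiproliferative activity; on this read-out higher numbers stand for weaker inhibition and lower numbers for stronger inhibition:
- compound 1 `Cn1ncc(Cl)c1-c1cc(C(=O)N[C@@H]2CN[C@H](CCN3CCC(O)CC3)C[C@H]2c2ccc(Cl)c(Cl)c2)oc1Cl`: 1140 nM
- compound 2 `C=CC[C@@H]1C[C@@H](c2ccc(Cl)c(Cl)c2)[C@H](NC(=O)c2cc(-c3c(Cl)cnn3C)c(Cl)o2)CN1`: 160 nM
- compound 3 `Cn1ncc(Cl)c1-c1cc(C(=O)N[C@@H]2CN[C@H](CC(=O)NC3CCC3)C[C@H]2c2ccc(Cl)c(Cl)c2)oc1Cl`: 80 nM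

Compound 1 gives the highest number of the three. Compound 2 differs from it by a 7.1-fold lower number from compound 1 to compound 2 (0.85 log units; beyond the scatter), compound 3 by a 14-fold lower number from compound 1 to compound 3 (1.15 log units; beyond the scatter); between compound 2 and compound 3 the step is a 2.0-fold lower number from compound 2 to compound 3 (0.30 log units; within the scatter), within the scatter.

Compound 4 `Cn1ncc(Cl)c1-c1cc(C(=O)N[C@@H]2CN[C@H](CCO)C[C@H]2c2ccc(Cl)c(Cl)c2)oc1Cl` is not yet measured in this assay. Relative to compound 1 the change is hydroxy in place of 4-hydroxypiperidin-1-yl on a saturated chain carbon, two bonds along the chain from a saturated ring carbon. Both measured steps bear on it, since each of them likewise removes the 4-hydroxypiperidin-1-yl group from this chain position: the step to compound 2 was modest, the step to compound 3 large, and both point to lower numbers. The remaining substituent in compound 4 is small and neutral like the vinyl of compound 2, so a step of similar size, downward, is expected, about a 4.6-fold lower number from compound 1 to compound 4 (0.66 log units; beyond the scatter). For compound 4 the estimated value is 250 nM, with a range of 80 nM to 800 nM.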

Compound 4, half-maximal inhibitory concentration: 160 nM
The estimate for compound 4 lay 1.6-fold (0.19 log units) above the measured number; the measured number falls inside the stated range.
By their numbers in this assay, from the lowest: compounds 3, 2 and 4 (each within the scatter of the next); then compound 1.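

In this assay, going by these compounds alone, the 4-hydroxypiperidin-1-yl group can be reduced to a lone hydroxy on the chain (a 7.1-fold lower number from compound 1 to compound 4 (0.85 log units; beyond the scatter)), and this step is the same size as the one from compound 1 to compound 2. Compound 4 keeps a hydroxy, whereas compound 2 and compound 3 have none, yet all three read alike (no change at the digits printed from compound 2 to compound 4 (within the scatter); a 2.0-fold higher number from compound 3 to compound 4 (0.30 log units; within the scatter)), so among the compounds shown the presence of a hydroxy does not separate compound 1 from the others. No measurement at hand accounts for these steps.

Open, as far as these compounds go, is whether a dimethylamino group in place of the hydroxy of compound 4 gives a number nearer compound 1 or compound 4. Also open, from the compounds shown here alone, is whether a longer chain ending in hydroxy, or a carboxylic acid at this place, stays level with compound 4.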